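Swapping a Pyrazole for Methoxy on an Inactive Core

The source may report more compounds than this note shows. Statements on the series, on what has been measured and on what is new or still open speak of the compounds shown alone.

Of the compounds shown here, two of a shared core have been tested in a functional assay on CHO cells for agonist activity at Alpha-1B adrenergic receptor (Homo sapiens), read by FLIPR and calcium flux (a lower number here means that less compound is needed, a higher number that more compound is needed for the effect), and neither gave a number. Compound 1, `COc1c(C)ccc2c1CCC2c1ncc[nH]1`, reached only the limit of the assay, reported as > 10000 nM. Compound 2, `Cn1ccc(-c2cccc3c2CCC3c2ncc[nH]2)n1`, likewise stopped at the limit, reported as > 10000 nM. So compound 2 stands at the edge of what this assay can see, a position it shares with compound 1, as the limit of > 10000 nM in this assay, at which 2 of the 2 values shown sit, states.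

Compound 3, `COc1cccc2c1CCC2c1ncc[nH]1`, is the next compound to be measured in this assay. It differs from compound 2 in one place: methoxy in place of 1-methyl-1H-pyrazol-3-yl on an aromatic carbon. Compound 1 also carries a methoxy group on the same kind of ring, together with a methyl group, and it gave no number either.

For the measured compounds named here, no measured step links these compounds, so the expectation rests on the two limits alone. The step from compound 2 to compound 3 is expected to be small, most likely none beyond the scatter, with compound 3 remaining near the limit, an estimated step that the limit leaves unreadable from compound 2 to compound 3. Compound 3 is therefore expected to give about 20000 nM, somewhere in the range from 5000 nM to 80000 nM, most probably reported as a limit rather than a number.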

Compound 3, half-maximal effective concentration: > 10000 nM
Compound 3: a limit, no number (the forecaster's own chance of this, stated with the estimate: 75%); the middle value is on the limit's open side.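

Compound 3, like compound 2 and compound 1, reaches only a limit in this assay, so the steps from compound 2 and from compound 1 to compound 3 cannot be read, and all three compounds share one result: the limit of > 10000 nM in this assay, at which 3 of the 3 values shown sit. The compounds shown leave open whether any change on the shared core can produce a measurable value in this assay.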